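Amide exchange on the shared core: expected binding of compound 3

The source may hold more compounds than are shown below. What is called first, only, known or untested is meant among the compounds shown, and "the series" means these compounds.

Compound 1 `Cc1cc(C(=O)Nc2ccccn2)nn1Cc1cc(Cl)ccc1OCc1ccccc1` has been measured in an assay on CHO-K1 cells for displacement of a labelled ligand from prostaglandin E2 receptor EP1 subtype (Homo sapiens) (a lower number here means a stronger inhibitor, a higher number a weaker inhibitor), and gives 126 nM. A second member of the series, compound 2 `Cc1cc(C(N)=O)nn1Cc1cc(Cl)ccc1OCC(C)C`, gives in this assay 126 nM. Compound 1 stands level with compound 2 at the digits shown; the two values lie within the usual scatter of each other, so neither can be placed above the other.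

Compound 3 `Cc1cc(NC(=O)C2CCCO2)nn1Cc1cc(Cl)ccc1OCc1ccccc1` has not yet been measured. It differs from compound 1 in one place: ((oxolan-2-yl)carbonyl)amino in place of (pyridin-2-yl)carbamoyl on an aromatic carbon. The group that leaves contains one six-membered aromatic ring with 1 hetero atom; the group that enters contains one five-membered non-aromatic ring with 1 hetero atom, while the counts of hydrogen-bond donors and acceptors stay the same.

Among the measured compounds shown here, no measured pair shows this change, so nothing in the data fixes its size. A step beyond the scatter toward weaker binding is expected in this assay, of moderate size, as given by a 3.2-fold higher number from compound 1 to compound 3 (0.50 log units; beyond the scatter). Compound 3 is expected to give 400 nM, with a range from 80 nM to 2000 nM.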

Compound 3, half-maximal inhibitory concentration: 39.8 nM
The estimate for compound 3 lay 10-fold (1.00 log units) above the measured number; measured number below the stated range.
By their numbers in this assay, from the lowest: compound 3; then compounds 1 and 2 (each within the scatter of the next).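

In this assay, among the compounds shown here, ((oxolan-2-yl)carbonyl)amino in place of (pyridin-2-yl)carbamoyl gives a 3.2-fold lower number from compound 1 to compound 3 (0.50 log units; beyond the scatter), the first step that can be read at this position on the five-membered aromatic ring. Binding at this position therefore does not depend on the six-membered aromatic ring of the leaving group: a five-membered non-aromatic ring with one hetero atom serves better here, with the counts of hydrogen-bond donors and acceptors unchanged. No measurement on hand bears on the reason for this gain.

The change also swaps the atom joined to the aromatic carbon, from the carbonyl carbon of the carbamoyl group to the nitrogen of the amino group, so the compounds shown cannot separate the effect of the ring from that of the amide direction. A (pyridin-2-yl)carbonylamino group or an (oxolan-2-yl)carbamoyl group at the same position would pull these two apart, and a simple acetylamino group would show how much of the step needs the oxolane ring at all.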